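Swapping One Aryl Group on a Shared Core

The source may hold more compounds than are shown below. What is called first, only, known or untested is meant among the compounds shown, and "the series" means these compounds.

Of the compounds shown here, three sharing a common core have been tested in a functional assay on MDA-MB-231 cells (Homo sapiens) for cytotoxicity, read by MTT assay, with a stated time of 48 h; on this read-out lower numbers stand for stronger inhibition and higher numbers for weaker inhibition. Compound 1 `Fc1cccc(-c2nc(Nc3ccccc3)c3ccccc3n2)c1` reaches only the limit of the assay, giving > 50000 nM. Compound 2 `Fc1ccc2nc(-c3ccccc3)nc(Nc3ccccc3)c2c1` also reaches only that limit, giving > 50000 nM. Compound 3 `Fc1cccc(-c2nc(Nc3ccc(Br)cc3)c3cc(F)ccc3n2)c1` likewise reaches only the limit, giving > 50000 nM. Compound 3 therefore stands at the same limit as the other two, and no order among the three can be drawn from the numbers; the whole picture is captured by the limit of > 50000 nM in this assay, at which 3 of the 3 values shown sit.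

Compound 4 `Cc1cccc(Nc2nc(-c3cccc(F)c3)nc3ccc(F)cc23)c1` has not yet been measured in this assay. It differs from compound 3 in one place: 3-methylphenyl in place of 4-bromophenyl on a nitrogen on an aromatic ring. Within the data shown here, no two measured compounds in this set differ in only one place, so there is no measured step to lean on. Every value seen so far is a limit rather than a number, and the expectation for compound 4 rests on that alone. The step from compound 3 to compound 4 is expected to be a number no higher from compound 3 to compound 4 (the limit leaves the size open), which amounts to none beyond the scatter, with the assay quite likely reporting a limit again. For compound 4 the estimated value is 50000 nM, expected to fall between 15000 nM and 100000 nM.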

Compound 4, half-maximal inhibitory concentration: > 50000 nM
Compound 4 ended at the assay's limit; the forecaster's own chance of this, stated with the estimate: 70%; the middle value sits exactly at the limit.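

Compound 3 and compound 4 both give a limit rather than a number in this assay, so the change from 4-bromophenyl to 3-methylphenyl yields no readable step. The compounds shown leave open whether any change to the shared core gives a measurable value, because all of them rest at one point: the limit of > 50000 nM in this assay, at which 4 of the 4 values shown sit.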